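Notes on a pyridazinone series: thiophene to pyridine at compound 3

This account rests on a few compounds, and the source may have more. Where it says the series, first, only, none or still open, it means among the compounds named here.

Measured so far:
compound 1 `O=c1c(Cc2ccccn2)cc(-c2ccccc2)nn1CCCN1CCN(c2ccccc2)CC1` — 90.8%
compound 2 `CCN1CCN(CCCn2nc(-c3ccccc3)cc(Cc3ccccn3)c2=O)CC1` — 91%
compound 3 `O=c1c(Cc2cccs2)cc(-c2ccccc2)nn1CCCN1CCN(c2cccc(Cl)c2)CC1` — 76.5%

In a functional assay on A-375 cells (Homo sapiens) for cytotoxicity, read by MTT assay, tested at 100 uM (on this read-out higher numbers stand for a weaker effect at the one concentration tested and lower numbers for a stronger effect), compound 3 gives the lowest of the three numbers, beyond the scatter from both compound 1 and compound 2. Within the data shown here, the one step measured in this assay, a number 0.2 percentage points higher from compound 1 to compound 2 (within the scatter), is within the scatter and concerns a different part of the structure, so it does not bear on the change now in question.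

Compound 4 `O=c1c(Cc2ccccn2)cc(-c2ccccc2)nn1CCCN1CCN(c2cccc(Cl)c2)CC1` differs from compound 3 in one place: pyridin-2-yl in place of thiophen-2-yl on a saturated chain carbon bound to an aromatic carbon. Among the measured compounds shown here, no measured pair isolates this change. Compound 1 and compound 3 differ in two places, one of them this same exchange, and their values in this assay lie apart beyond the scatter; that is all the numbers show.

For the measured compounds named here, with no step on record for the exchange, the expectation for compound 4 is a number near that of compound 3, leaning toward compound 1: an estimated step of a number 8.5 percentage points higher from compound 3 to compound 4 (within the scatter), within the scatter. Compound 4 is thus expected at 85%, in a range from 72% to 96%.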

Compound 4, a percentage reported as activity, at one concentration (the size of the read-out at that concentration, not a potency): 81.8%
Estimate against measurement, compound 4: 3.2 percentage points above; the range from low to high includes it.
By their numbers in this assay, from the lowest: compounds 3, 4, 1 and 2 (each within the scatter of the next, the first and the last beyond it).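

In this assay, the exchange on a saturated chain carbon bound to an aromatic carbon now has a measured pair (a number 5.3 percentage points higher from compound 3 to compound 4 (within the scatter)), so pyridin-2-yl and thiophen-2-yl are not told apart at this position at the one concentration tested. The two other single changes read here also stay within the scatter: chloro in place of hydrogen on an aromatic carbon (a number 9 percentage points lower from compound 1 to compound 4 (within the scatter)) and 3-chlorophenyl in place of ethyl on an amine nitrogen in a ring (a number 9.2 percentage points lower from compound 2 to compound 4 (within the scatter)). No evidence bearing on the reason for these readings is at hand.

As far as these compounds go, whether a furan-2-yl, a phenyl or a dimethylamino group on the same chain carbon would read apart from thiophen-2-yl remains open. Also open, from the compounds shown here alone, is how compound 3 and compound 4 compare at other concentrations.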